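Shifting a methoxy group on two related cores

The source may report more compounds than this note shows. Statements on the series, on what has been measured and on what is new or still open speak of the compounds shown alone.

Measured compounds:
- Compound 1 `COc1ccccc1/C=C/C(=O)/C=C/c1ccc(OCc2cn(CCCOc3cc(=O)oc4ccccc34)nn2)c(OC)c1`, in a functional assay on COLO 205 cells (Homo sapiens) for inhibition, read by sulforhodamine B assay, with a stated time of 48 h, tested at 50 uM (a higher number here means more inhibition of growth at the concentration tested, a lower number less inhibition of growth), gives 57%.
- Compound 2 `COc1ccc(/C=C/C(=O)/C=C/c2ccc(OCc3cn(CCCOc4cc(=O)oc5ccccc45)nn3)c(OC)c2)cc1` gives 53% in this assay.
- Compound 3 `COc1ccccc1/C=C/C(=O)/C=C/c1ccc(OCc2cn(CCOc3cc(=O)oc4ccccc34)nn2)c(OC)c1` gives 67% in this assay.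

Compound 1 and compound 2 share one core and differ in a single place: 4-methoxyphenyl in place of 2-methoxyphenyl on a double-bonded chain carbon bound to a double-bonded chain carbon. This change gives a number 4 percentage points lower from compound 1 to compound 2 (within the scatter), so the two values cannot be told apart by this assay.

Compound 3 is built on a different core, and the difference between the two cores is not broken down here. Its value in this assay and that of compound 1 lie within the usual scatter of each other, so no order between them is claimed. Compared with compound 2, the value of compound 3 is higher by more than the scatter.

Compound 4 `COc1ccc(/C=C/C(=O)/C=C/c2ccc(OCc3cn(CCOc4cc(=O)oc5ccccc45)nn3)c(OC)c2)cc1` is not yet measured. It stands to compound 3 as compound 2 stands to compound 1: the difference is 4-methoxyphenyl in place of 2-methoxyphenyl on a double-bonded chain carbon bound to a double-bonded chain carbon, the same change at the same place. Because the earlier change gave a number 4 percentage points lower from compound 1 to compound 2 (within the scatter), the step from compound 3 to compound 4 is expected to be small as well, about a number 4 percentage points lower from compound 3 to compound 4 (within the scatter). On that basis compound 4 is estimated to give about 63% in this assay, most likely between 51% and 75%. This expectation rests on a single measured pair and on compound 3 alone.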

Compound 4, percent growth inhibition at one concentration: 68%
Compound 4: middle estimate off by 5 percentage points, on the low side; the measured number falls inside the stated range.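

On the second core, 4-methoxyphenyl in place of 2-methoxyphenyl gives a number 1 percentage points higher from compound 3 to compound 4 (within the scatter) in this assay, so here too the assay cannot tell the two compounds apart. Set beside the same change on the first core, the new step does not differ from the earlier one by more than the assay can resolve: the same change on two cores in this assay, a number 4 percentage points lower (within the scatter) from compound 1 to compound 2 and a number 1 percentage points higher (within the scatter) from compound 3 to compound 4, 5 percentage points apart, within the scatter of two such steps. This shows that the change carried over from one core to the other without a step beyond the scatter on either, but it does not prove that the change has no effect, since a small effect could be hidden in the scatter, and it rests on just two pairs tested in one assay at one concentration.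

The compounds shown leave open whether a larger step would appear if either methoxyphenyl group gave way to a plain phenyl or to a phenyl carrying an amine or a carboxylic acid. They also leave open whether the change would behave the same way on a core with a longer chain, or in a different kind of assay.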